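This account rests on a few compounds, and the source may have more. Where it says the series, first, only, none or still open, it means among the compounds named here.

Compound 3, `O=C(NO)c1ccc(NCc2nc(-c3ccc(Cl)cc3)nn2-c2ccccc2)cc1`, sits second highest of the three compounds measured in an assay on Sf9 cells for inhibition of protein deacetylase HDAC6 (Homo sapiens), read by fluorescence, with a stated time of 40 min, tested at 100 nM (on this read-out higher numbers stand for more inhibition at the one concentration tested (going by the name of the read-out) and lower numbers for less inhibition), where compound 3 gives 67.2%. Compound 2, `O=C(NO)c1ccc(NCc2nc(-c3ccc(F)cc3)nn2-c2ccccc2)cc1`, gives 70.9% in this assay, and the step of a number 3.7 percentage points lower from compound 2 to compound 3 (within the scatter) is within the scatter, so these two cannot be ordered. Compound 1, `O=C(NO)c1ccc(NCc2nc(-c3ccc(Br)cc3)nn2-c2ccccc2)cc1`, gives 54.7%, and the step of a number 12.5 percentage points higher from compound 1 to compound 3 (beyond the scatter) lies beyond the scatter, as does a number 16.2 percentage points higher from compound 1 to compound 2 (beyond the scatter). Compound 4, `CCc1ccc(-c2nc(CNc3ccc(C(=O)NO)cc3)n(-c3ccccc3)n2)cc1`, differs from compound 3 by ethyl in place of chloro on an aromatic carbon. Among the compounds with values here, no measured step exchanges a halogen for ethyl, so the halogen steps bear on it only indirectly: the bromo-to-chloro and bromo-to-fluoro steps show that this position can shift the read-out by a modest amount, whereas chloro against fluoro does not. A modest change in this assay is therefore expected, with its direction uncertain, and compound 4 is estimated at 58% with a range from 40% to 74%, a step of a number 9.2 percentage points lower from compound 3 to compound 4 (within the scatter) that is expected to stay near the scatter.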

Compound 4, a percentage reported as inhibition, at one concentration (the size of the read-out at that concentration, not a potency): 54.6%
Compound 4: the middle estimate sits 3.4 percentage points above what was measured; the range from low to high includes it.
By their numbers in this assay, from the lowest: compounds 4 and 1 (each within the scatter of the next); then compounds 3 and 2 (each within the scatter of the next).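

In this assay, the change from 4-chlorophenyl to 4-ethylphenyl gives this position a direction that the halogen steps alone could not: a number 12.6 percentage points lower from compound 3 to compound 4 (beyond the scatter) and a number 16.3 percentage points lower from compound 2 to compound 4 (beyond the scatter) both place ethyl with a lower number than chloro or fluoro. Against bromo there is no such separation, since a number 0.1 percentage points lower from compound 1 to compound 4 (within the scatter) means compound 1 and compound 4 cannot be ordered, and a group that is not a halogen can thus read the same as bromo here. No independent measurement offers a reason for this pattern.

From the compounds shown here alone, it stays open how an amine, a carboxylic acid, a methoxy group or a longer chain such as butyl would read at this position. Going by these compounds, because each value comes from one concentration, it also remains open whether these steps would carry over to potency.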